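This account rests on a few compounds, and the source may have more. Where it says the series, first, only, none or still open, it means among the compounds named here.

Measured in a functional assay on HCT-116 cells (Homo sapiens) for cytotoxicity, read by scintillation counting and thymidine incorporation, with a stated time of 72 h; a higher number here means a weaker inhibitor, a lower number a stronger inhibitor:
- compound 1 `COc1cc(OC)cc(C(=CC#N)c2ccc(OC)c(N)c2)c1`: 1.4 nM
- compound 2 `COc1cc(OC)cc(C(=CCCN(C)C)c2ccc(OC)c(OC)c2)c1`: > 10000 nM (a limit of the assay, not a number)
- compound 3 `COc1cc(OC)cc(C(=CC(C)=O)c2ccc(OC)c(OC)c2)c1`: > 10000 nM (a limit of the assay, not a number)

Within the data shown here, compound 1 holds the only true number in this small set. Compounds 2 and 3 give no number, as they stand at the limit of > 10000 nM in this assay, at which 2 of the 3 values shown sit.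

The next compound to be tested is compound 4 `COc1ccc(C(=CC#N)c2cc(OC)cc(OC)c2)cc1`. It differs from compound 1 by one change, hydrogen in place of amino on an aromatic carbon.

The measured data offer little guidance on this change. Among the measured compounds shown here, the single measured step is a step that the two limits leave unreadable from compound 2 to compound 3, and it lies at a different place in the structure, so it gives no size to carry over. For the measured compounds named here, no measured step removes the amino group. The expectation therefore rests on the starting point alone. With compound 1 at 1.4 nM, a low value that the other two compounds in this set do not reach, a change has more room to lose activity than to gain it.

The expected change is a 110-fold higher number from compound 1 to compound 4 (2.03 log units; beyond the scatter), an estimated move toward weaker inhibition in this assay. For compound 4 the estimated value is 150 nM, with an expected range from 8 nM to 3000 nM.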

Compound 4, half-maximal inhibitory concentration: 1.2 nM
Compound 4: the middle estimate sits 130-fold (2.10 log units) above what was measured, outside the stated range (below it).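

In this assay, putting hydrogen in place of amino on this aromatic carbon, ortho to a methoxy group, gives a 1.2-fold lower number from compound 1 to compound 4 (0.07 log units; within the scatter), so the two values cannot be told apart. The amino group, with the hydrogen-bond donor and acceptor counted for it, is therefore not required at this position for a low value, as compound 4 still reaches 1.2 nM without it. Nothing in the data shown explains why this change leaves the value in place.

From the compounds shown here alone, at this carbon only amino and hydrogen can be compared on the nitrile-bearing compounds, so it stays open whether a hydroxyl group, a fluorine atom or a longer chain such as ethoxy would also keep the value low. Going by these compounds, a methoxy group at this carbon on the same nitrile-bearing structure also remains open: compounds 2 and 3 carry one, but they differ from compound 1 in more than one place, and each gives only a limit of the assay, not a number.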